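The source may report more compounds than this note shows. Statements on the series, on what has been measured and on what is new or still open speak of the compounds shown alone.

In a functional assay on A549 cells (Homo sapiens) for cytotoxicity, read by MTT assay, with a stated time of 48 h (a lower number here means a stronger inhibitor, a higher number a weaker inhibitor), compound 1 (`O=C(O)CN1C(=O)/C(=C/c2nc3ccccc3n2Cc2ccc(Br)cc2F)SC1=S`) gives 27300 nM and sits at the upper end of the series, level with compound 3 (`O=C(O)CN1C(=O)/C(=C/c2nc3ccccc3n2Cc2ccc(C(F)(F)F)cc2)SC1=S`) at 25300 nM with a 1.1-fold lower number from compound 1 to compound 3 (0.03 log units; within the scatter) between them. Compound 2 (`O=C(O)CN1C(=O)/C(=C/c2nc3ccccc3n2Cc2ccccc2)SC1=S`) lies lower at 8760 nM on this measure. Compound 4 (`O=C(O)CN1C(=O)/C(=C/c2nc3ccccc3n2Cc2ccccc2F)SC1=S`) alters compound 1 in one place (hydrogen in place of bromo on an aromatic carbon), with hydrogen in place of bromo on an aromatic carbon, while the fluoro group stays. Within the data shown here, no measured step makes this swap alone. The closest is a 3.1-fold lower number from compound 1 to compound 2 (0.49 log units; beyond the scatter) where bromo and fluoro leave together, and a 2.9-fold higher number from compound 2 to compound 3 (0.46 log units; beyond the scatter) mirrors it where trifluoromethyl replaces hydrogen. A modest fall is therefore expected in this assay and no larger than the first of these. The estimated change is a 2.1-fold lower number from compound 1 to compound 4 (0.32 log units; beyond the scatter) in all. Compound 4 is expected at 13000 nM as an estimate, within an expected range from 7000 nM to 25000 nM overall.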

Compound 4, half-maximal inhibitory concentration: 2670 nM
Beside the measured number, compound 4's estimate is 4.9-fold (0.69 log units) above it, outside the stated range (below it).
By their numbers in this assay, from the lowest: compound 4; then compound 2; then compounds 3 and 1 (each within the scatter of the next).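

In this assay taking the bromo off the aromatic carbon while the fluoro stays gives a 10-fold lower number from compound 1 to compound 4 (1.01 log units; beyond the scatter) and so goes well past the step seen when both groups left together. The fluoro, whose share that earlier step could not show, now reads alone as a 3.3-fold lower number from compound 2 to compound 4 (0.52 log units; beyond the scatter) without any bromo present, and a 9.5-fold lower number from compound 3 to compound 4 (0.98 log units; beyond the scatter) puts this 2-fluorobenzyl group clear of the 4-(trifluoromethyl)phenyl one as well. Nothing available gives a reason for these shifts. From the compounds shown here alone, whether chloro or methoxy on that aromatic carbon, para to a large group, would act as hydrogen does stays open. So does whether the fluoro step would hold with such a group present.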